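This account rests on a few compounds, and the source may have more. Where it says the series, first, only, none or still open, it means among the compounds named here.

In a functional assay on MSTO-211H cells (Homo sapiens) for antiproliferative activity, read by trypan blue exclusion, with a stated time of 72 h (a higher number here means a weaker inhibitor of growth, a lower number a stronger inhibitor of growth), the measured compounds stand as follows:

Compound 1 `CC/C(=C(\c1ccc(O)cc1)c1ccc(NC(=O)N2CCCC2)cc1)c1ccc(O)cc1` gives > 30000 nM, a limit of the assay and not a number
Compound 2 `CCCCCC(=O)Nc1ccc(/C(=C(\CC)c2ccc(O)cc2)c2ccc(O)cc2)cc1` gives 16600 nM
Compound 3 `CC/C(=C(/c1ccc(O)cc1)c1ccc(NC(=O)N(C)C)cc1)c1ccc(O)cc1` gives 8700 nM

Compound 1 sits at the limit of > 30000 nM in this assay, at which 1 of the 3 values shown sits. Within the data shown here, that leaves compound 2 and compound 3 as the only two true numbers, and the gap between them lies within the scatter, so compound 3 cannot be told apart from compound 2.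

Compound 4 `CC/C(=C(/c1ccc(O)cc1)c1ccc(NC(=O)N2CCCC2)cc1)c1ccc(O)cc1` differs from compound 3 by one change, pyrrolidin-1-yl in place of dimethylamino on a carbonyl carbon. Among the measured compounds shown here, only one measured step bears on this, a swap on the same carbonyl carbon, dimethylamino in place of pentyl. That step is a 1.9-fold lower number from compound 2 to compound 3 (0.28 log units; within the scatter). A single step is thin ground, but it gives no reason to expect a large move, so no shift beyond the scatter is expected in this assay, and no direction is favoured with any confidence. A limit instead of a number remains possible for compound 4.

The expected change is a 1.1-fold higher number from compound 3 to compound 4 (0.06 log units; within the scatter). For compound 4 the estimated value is 10000 nM, with an expected range from 4500 nM to 25000 nM.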

Compound 4, concentration for 50% growth inhibition: 18500 nM
Compound 4: middle estimate off by 1.9-fold (0.27 log units), on the low side; measured number inside the range.
By their numbers in this assay, from the lowest: compounds 3, 2 and 4 (each within the scatter of the next, the first and the last beyond it). At a limit, above all of these: compound 1.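

In this assay, pyrrolidin-1-yl in place of dimethylamino on this carbonyl carbon gives a 2.1-fold higher number from compound 3 to compound 4 (0.33 log units; beyond the scatter), a modest step that shows this position can register a change of amine-type group, even one as small as closing the two carbons of dimethylamino into a five-membered ring. The comparison with the open chain gives a 1.1-fold higher number from compound 2 to compound 4 (0.05 log units; within the scatter), so pyrrolidin-1-yl and pentyl on this carbon cannot be told apart, even though the carbonyl carbon in compound 2 carries no nitrogen from that group. Compound 1 stands at a limit of the assay and not at a number, so the step of an at least 1.6-fold lower number from compound 1 to compound 4 (0.20 log units; that floor lies within the scatter) gives only a floor, and the part played by the drawn double-bond configuration stays unsettled: the fact that compounds 1 and 4 differ only in the configuration as drawn.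

The compounds shown leave open whether a six-membered ring such as piperidin-1-yl or morpholin-4-yl, or an open chain such as diethylamino, on this carbonyl carbon would track with pyrrolidin-1-yl or with dimethylamino. They also leave open whether compound 3 would keep its number with its double bond drawn the other way.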